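Swapping 4-fluorophenyl for thiophen-2-yl in compound 2

This account rests on a few compounds, and the source may have more. Where it says the series, first, only, none or still open, it means among the compounds named here.

Of the compounds shown here, three have been measured so far in a functional assay on U2OS cells (Homo sapiens) for antiproliferative activity, read by MTT assay, with a stated time of 72 h; on this read-out higher numbers stand for weaker inhibition and lower numbers for stronger inhibition. Compound 1 `O=C(Cc1nnc(NC(=O)c2ccc(Cl)cc2)s1)N/N=C/c1ccc(O)cc1` gives > 100000 nM, which is a limit of the assay and not a number. Compound 2 `O=C(CSc1cccc(O)c1)Nc1ccc2nc(NC(=O)c3ccc(F)cc3)sc2c1` gives 5120 nM, the higher of the two actual numbers. Compound 3 `O=C(CSc1ccc(Cl)cc1)Nc1ccc2nc(NC(=O)c3ccc(F)cc3)sc2c1` gives 2510 nM.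

The next compound to be tested is compound 4 `O=C(CSc1cccc(O)c1)Nc1ccc2nc(NC(=O)c3cccs3)sc2c1`, which differs from compound 2 in a single group: thiophen-2-yl in place of 4-fluorophenyl on a carbonyl carbon. Put simply, thiophen-2-yl stands in place of 4-fluorophenyl on a carbonyl carbon, and the rest of the molecule stays the same.

Among the measured compounds shown here, no measured step touches this carbonyl position. For the measured compounds named here, the only step available is a 2.0-fold lower number from compound 2 to compound 3 (0.31 log units; beyond the scatter), where 4-chlorophenyl takes the place of 3-hydroxyphenyl on a sulfur. That change lies elsewhere in the molecule, so it offers a rough sense of size, which is modest, and no guide to direction. In this assay a small step of uncertain direction is therefore expected, possibly none beyond the scatter. The estimated change is a 1.1-fold lower number from compound 2 to compound 4 (0.06 log units; within the scatter). For compound 4 the expected value is 4500 nM, with an estimated range from 1700 nM to 12000 nM.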

Compound 4, half-maximal inhibitory concentration: 63000 nM
The estimate for compound 4 lay 14-fold (1.15 log units) below the measured number; the whole stated range lies below it.
By their numbers in this assay, from the lowest: compound 3; then compound 2; then compound 4. At a limit, above all of these: compound 1.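

The carbonyl position turns out to be sensitive to the group it carries: in this assay, thiophen-2-yl in place of 4-fluorophenyl gives a 12-fold higher number from compound 2 to compound 4 (1.09 log units; beyond the scatter), so inhibition is much weaker with the five-membered ring. Among the compounds shown here, this large step outweighs the only other step available, the modest 2.0-fold lower number from compound 2 to compound 3 (0.31 log units; beyond the scatter) at the far end of the molecule on the sulfur, which suggests that a change at the carbonyl can matter more than one on the sulfur, though one step at each place is thin support. Weak as it is, compound 4 still gives a real number rather than reaching the limit of the assay, so the size of this step can be read in full: the limit of > 100000 nM in this assay, at which 1 of the 4 values shown sits.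

Going by these compounds, this single swap changes the ring size, brings in a ring sulfur and removes the fluorine all at once, so it remains open which of these matters; a plain phenyl, a furan-2-yl or a thiophen-3-yl on the same carbonyl would begin to separate them. On these data alone, it is also open whether thiophen-2-yl costs as much when 4-chlorophenyl sits on the sulfur, as it does in compound 3.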